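Extending a diol arm with a hydroxyethylamine tail

The source may hold more compounds than are shown below. What is called first, only, known or untested is meant among the compounds shown, and "the series" means these compounds.

Measured so far:
- compound 1, `CCCCCCCCCO[C@@H]1[C@@H](N)[C@@H](OCC(O)CO)O[C@H](CN)[C@H]1OCCCCCCCCC`: 8.8%
- compound 2, `C=CCO[C@H]1O[C@H](CN)[C@@H](O)[C@H](O)[C@H]1N`: 82.1%

In a toxicity assay on the whole organism (J774 cells) for cytotoxicity, with Mus musculus as the target, read by MTT assay, with a stated time of 24 h, tested at 30 uM (on this read-out higher numbers stand for a weaker effect at the one concentration tested and lower numbers for a stronger effect), compound 1 gives the lower of the two numbers, and compound 2 gives a number far higher, beyond the scatter. Compound 3, `CCCCCCCCCO[C@@H]1[C@@H](N)[C@@H](OCC(O)CNCCO)O[C@H](CN)[C@H]1OCCCCCCCCC`, is not yet measured. It differs from compound 1 in one place: (2-hydroxyethyl)amino in place of hydroxy on a saturated chain carbon, two bonds along the chain from an oxygen on a saturated carbon. Among the measured compounds shown here, no measured pair shows this change, so the step is estimated from compound 1 alone. Compound 3 is expected to keep a low number, with a small rise of a number 6.2 percentage points higher from compound 1 to compound 3 (within the scatter) in this assay that may not exceed the scatter. The estimate for compound 3 is 15%, within 3% to 40%.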

Compound 3, a percentage reported as activity, at one concentration (the size of the read-out at that concentration, not a potency): 10.1%
Compound 3: middle estimate off by 4.9 percentage points, on the high side; low and high end bracket the measured number.
By their numbers in this assay, from the lowest: compounds 1 and 3 (each within the scatter of the next); then compound 2.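

In this assay, (2-hydroxyethyl)amino in place of hydroxy gives a number 1.3 percentage points higher from compound 1 to compound 3 (within the scatter) and so leaves the read-out within the scatter. The earlier compounds shown here could not show this: on this saturated chain carbon, the end of the diol arm takes the longer hydroxyethylamine tail with no shift that can be told from the scatter. Nothing measured here gives a reason for this result.

On these data alone, whether a carboxylic acid or a plain amine on this carbon would read the same stays open. So does the effect of a longer chain on the tail.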